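This account rests on a few compounds, and the source may have more. Where it says the series, first, only, none or still open, it means among the compounds named here.

Compound 1 `Cc1ccc(-c2nc3ccccn3c2Sc2ccccc2)cc1`: > 100000 nM
Compound 2 `CSc1ccc(-c2nc3ccccn3c2Sc2ccccc2)cc1`: 23500 nM

In a functional assay on MDA-MB-231 cells (Homo sapiens) for inhibition, read by MTT assay, with a stated time of 48 h (a higher number here means a weaker inhibitor, a lower number a stronger inhibitor), compound 1 gives > 100000 nM, which is a limit of the assay and not a number. Its exact standing is therefore unknown, and it can only be placed at the weak end of the two values. Compound 2 `CSc1ccc(-c2nc3ccccn3c2Sc2ccccc2)cc1` gives a measurable 23500 nM. Within the data shown here, the one measured step is an at least 4.2-fold lower number from compound 1 to compound 2 (0.62 log units; beyond the scatter), made by putting methylsulfanyl in place of methyl on an aromatic carbon.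

Compound 3 `Cc1ccc(-c2nc3ccc(C)cn3c2Sc2ccccc2)cc1` keeps that methyl and changes the core instead: methyl in place of hydrogen on an aromatic carbon. The new methyl sits on an aromatic carbon of a six-membered aromatic ring with 1 nitrogen. Among the measured compounds shown here, no measured compound tests a change at this place, so an at least 4.2-fold lower number from compound 1 to compound 2 (0.62 log units; beyond the scatter) offers only a loose guide to what a single substituent can do, and no firm direction. A small step that leaves the compound near the limit is the most reasonable expectation. The estimated step is a number no higher from compound 1 to compound 3 (the limit leaves the size open). For compound 3 the expected value is 100000 nM, with an estimated range of 30000 nM to 300000 nM.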

Compound 3, half-maximal inhibitory concentration: 38000 nM
Estimate against measurement, compound 3: 2.6-fold (0.42 log units) above; the range from low to high includes it.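

In this assay, placing a single methyl on the core, rather than changing the group on the other ring, gives an at least 2.6-fold lower number from compound 1 to compound 3 (0.42 log units; beyond the scatter). This shows that a position on an aromatic carbon of a six-membered aromatic ring with 1 nitrogen can also move the result, and that a group of only one carbon is enough to bring a compound into the measurable range, with compound 3 at 38000 nM. The true size of this step stays unknown, as compound 1 is known only through a limit of the assay, which is not a number: the limit of > 100000 nM in this assay, at which 1 of the 3 values shown sits.

Hydrogen and methyl are the only groups shown at this position, so it remains open whether a longer chain, an amine or a carboxylic acid there would give a lower or a higher number. Also open, from the compounds shown here alone, is what a single compound would give if it carried both the methylsulfanyl group of compound 2 and the new methyl of compound 3, as the two changes are seen only separately.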